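The source may hold more compounds than are shown below. What is called first, only, known or untested is meant among the compounds shown, and "the series" means these compounds.

In a physicochemical assay for solubility, read by nephelometry, at pH 2 (on this read-out higher numbers stand for higher solubility and lower numbers for lower solubility), compound 1 `CC(C)c1cnc(NC(=O)CCCOc2ccccc2)s1` gives < 1200 nM, which is a limit of the assay and not a number. Compound 3 `N#Cc1cnc(NC(=O)CCCOc2cccc(C(F)(F)F)c2)s1` gives < 1600 nM, and this too is a limit. Only compound 2 `Cc1cnc(NC(=O)CCCOc2cncc(Cl)c2)s1` gives a number, at 1600 nM. Compound 1 therefore has no exact standing among these values. Compound 4 `O=C(CCCOc1ccccc1)Nc1ncc(Cl)s1` has not yet been measured. It differs from compound 1 by chloro in place of isopropyl on an aromatic carbon, with chloro in place of isopropyl on an aromatic carbon, next to the ring sulfur. For the measured compounds named here, no measured pair shows this change. Going by the values given here, with compound 2 at 1600 nM as the only number, no step beyond the scatter is expected in this assay. The expected change is a number no lower from compound 1 to compound 4 (the limit leaves the size open). The estimate for compound 4 is 1200 nM, with an expected range of 600 nM to 2500 nM.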

Compound 4, solubility: < 1200 nM
Compound 4: a limit, no number; the forecaster's own chance of this, stated with the estimate: 55%; the middle value lies on the limit itself.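

For the compounds shown here, compound 1 and compound 4 both give only a limit in this assay, so no step between them can be read. The compounds shown leave open whether chloro in place of isopropyl changes the read-out at all.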